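A few compounds are considered here, and "the series" means these few. Any claim that something is new, unique, unknown or untested is made for them only; others in the source may bear on it.

Working notes on the series.

Three compounds carry a measurement in a functional assay on SGC-7901 cells (Homo sapiens) for antiproliferative activity, read by sulforhodamine B assay, with a stated time of 72 h; on this read-out higher numbers stand for weaker inhibition and lower numbers for stronger inhibition. Compound 1 `Fc1cccc(NC(=S)N/N=C/c2ccc3ccccc3n2)c1` gives 79900 nM and stands highest of the three. Compound 2 `CN(C)C(=S)N/N=C/c1cnc2ccccc2n1` gives 170 nM in this assay, the lowest of the three numbers, and compound 3 `CN(C)C(=S)N/N=C/c1ccc2cccnc2n1` gives 630 nM. The gap between compound 1 and each of the other two is far beyond the usual scatter. Compound 1 is thus the weakest inhibitor of the three measured here. Among the measured compounds shown here, compounds 2 and 3 differ from compound 1 in more than one place, and no single step among them is isolated.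

Compound 4 `Fc1ccc(NC(=S)N/N=C/c2ccc3ccccc3n2)cc1` is not yet measured. It differs from compound 1 as follows: 4-fluorophenyl in place of 3-fluorophenyl on an amide-type nitrogen. The two have the same atoms joined differently. For the measured compounds named here, no measured pair in the set isolates this kind of change, so there is nothing to calibrate it against.

A step of about none beyond the scatter is expected, which is what a 1.3-fold lower number from compound 1 to compound 4 (0.12 log units; within the scatter) means here. Compound 4 is estimated at 60000 nM in this assay, within a range from 20000 nM to 200000 nM.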

Compound 4, half-maximal inhibitory concentration: 32300 nM
Compound 4: middle estimate off by 1.9-fold (0.27 log units), on the high side, within the range that was stated.
By their numbers in this assay, from the lowest: compound 2; then compound 3; then compound 4; then compound 1.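

In this assay, 4-fluorophenyl in place of 3-fluorophenyl on the amide-type nitrogen gives a 2.5-fold lower number from compound 1 to compound 4 (0.39 log units; beyond the scatter), a modest step and the first single change isolated in this series. The atoms stay the same and only their joining differs, so a change in where the fluorine sits on this group is enough to move the number beyond the scatter. No measurement at hand bears on what lies behind this step.

The compounds shown leave open whether the step is particular to fluorine or recurs with a chlorine atom or a methoxy group on the phenyl ring. Also open, as far as these compounds go, is how an unsubstituted phenyl or a dimethylamino group on the thiocarbonyl carbon would compare on the core of compound 1.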